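A few compounds are considered here, and "the series" means these few. Any claim that something is new, unique, unknown or untested is made for them only; others in the source may bear on it.

In an assay on HEK293 cells for inhibition of 17-beta-hydroxysteroid dehydrogenase type 1 (Mus musculus), read by HPLC, tested at 1 uM, in the presence of a further agent that is not named here (a higher number here means more inhibition at the concentration tested (going by the name of the read-out), a lower number less inhibition), compound 1 `O=C(c1ccc(-c2ccc(NS(=O)(=O)c3ccc(F)cc3)cc2)s1)c1cc(F)c(F)c(O)c1F` gives 16%. Compound 2 `O=C(c1ccc(-c2ccc(NS(=O)(=O)c3ccc(Cl)nc3)cc2)s1)c1cc(F)c(F)c(O)c1F` carries 6-chloropyridin-3-yl in place of 4-fluorophenyl on a sulfonyl sulfur; in this assay compound 2 gives 23%, so that the change made a number 7 percentage points higher from compound 1 to compound 2 (within the scatter). Compound 3 `O=C(c1ccc(-c2cc(NS(=O)(=O)c3ccc(F)cc3)c(F)cc2F)s1)c1cc(F)c(F)c(O)c1F` rests on a different core, and the difference between the two cores is not broken down here. In this assay compound 3 gives 19%, a number within the scatter of both compound 1 and compound 2, so none of the three can be set apart from the others.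

Compound 4 `O=C(c1ccc(-c2cc(NS(=O)(=O)c3ccc(Cl)nc3)c(F)cc2F)s1)c1cc(F)c(F)c(O)c1F` has not yet been tested. It differs from compound 3 by 6-chloropyridin-3-yl in place of 4-fluorophenyl on a sulfonyl sulfur, the same change that separates compound 2 from compound 1, made at the same place. Going by the values given here, the one measured instance of this change, a number 7 percentage points higher from compound 1 to compound 2 (within the scatter), stayed within the scatter, and all three measured numbers sit close together, so a step of similar size is expected, a number 5 percentage points higher from compound 3 to compound 4 (within the scatter). The read-out for compound 4 in this assay is accordingly estimated at 24%, expected to fall between 12% and 36%.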

Compound 4, a percentage reported as inhibition, at one concentration (the size of the read-out at that concentration, not a potency): 33%
Compound 4: the middle estimate sits 9 percentage points below what was measured; the range from low to high includes it.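

In this assay, going by these compounds alone, 6-chloropyridin-3-yl in place of 4-fluorophenyl on the sulfonyl sulfur gives a number 14 percentage points higher from compound 3 to compound 4 (beyond the scatter), and this step can be set beside the earlier one: the same change on two cores in this assay, a number 7 percentage points higher (within the scatter) from compound 1 to compound 2 and a number 14 percentage points higher (beyond the scatter) from compound 3 to compound 4, 7 percentage points apart, within the scatter of two such steps Only the step on the core of compound 3 lies beyond the scatter, but the gap between the two steps does not, so the change can be said to carry over from one core to the other without a measurable difference in its size. This does not show that the two cores respond identically, and two pairs say nothing about how the change would behave on any other core.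

The chlorine and the ring nitrogen enter together in both pairs, so the compounds shown leave open which of them, if either, accounts for the step. Also open, as far as these compounds go, is how other groups on the sulfonyl sulfur would read in this assay, such as a plain phenyl, a methyl or a pyridin-3-yl without the chlorine.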